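The compounds below may be only part of what the source reports. "The series", "measured", "known", "first", "only" and "open" are said of these compounds alone.

Working notes on the series, measured in a functional assay on HeLa cells (Homo sapiens) for inhibition, read by CCK-8 assay, with a stated time of 72 h, tested at 8 uM; a lower number here means less inhibition of growth, a higher number more inhibition of growth at the concentration tested:

- compound 1 `Nc1ccccc1NC(=O)c1ccc(CSc2cccc(F)c2)cc1` gives 78.4%
- compound 2 `Cc1ccc(SCc2ccc(/C=C/C(=O)Nc3ccccc3N)cc2)cc1` gives 21.7%
- compound 3 `Cc1ccc(SCc2ccc(C(=O)Nc3ccccc3N)cc2)cc1` gives 79.2%

Compound 3 (79.2%) and compound 1 (78.4%) lie within the scatter of each other, and compound 2 (21.7%) lies far lower than both.

Still unmeasured is compound 4 `Nc1ccccc1NC(=O)c1ccc(CSc2ccc(F)cc2)cc1`, reached from compound 3 by one change: fluoro in place of methyl on an aromatic carbon, in words fluoro in place of methyl on an aromatic carbon, para to a large group, so that 4-methylphenyl becomes 4-fluorophenyl.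

Among the compounds with values here, one measured step bears on this: a number 0.8 percentage points higher from compound 1 to compound 3 (within the scatter), with 4-methylphenyl in place of 3-fluorophenyl on a sulfur. That step touches the same aryl group on the sulfur and also swaps a fluoro-bearing ring for a methyl-bearing one. Compound 2 carries the same 4-methylphenyl as compound 3, so it says nothing about this change. Within the data shown here, the evidence is thin, since it is a single step and no compound with 4-fluorophenyl has been measured yet. No step beyond the scatter is therefore expected in this assay for this change.

The expected step is a number 2.2 percentage points lower from compound 3 to compound 4 (within the scatter), within the scatter. For compound 4 the estimated value is 77%, with an expected range of 65% to 88%.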

Compound 4, percent growth inhibition at one concentration: 79.3%
Compound 4: the middle estimate sits 2.3 percentage points below what was measured; the range from low to high includes it.
By their numbers in this assay, from the lowest: compound 2; then compounds 1, 3 and 4 (each within the scatter of the next).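

Fluoro in place of methyl on an aromatic carbon, para to a large group, gives a number 0.1 percentage points higher from compound 3 to compound 4 (within the scatter) in this assay, so this position has now been read directly with two different groups on the same aryl ring, and the read-out does not separate them. Within the data shown here, the comparison of the two fluorophenyl groups gives a number 0.9 percentage points higher from compound 1 to compound 4 (within the scatter), which adds the first direct reading of where the fluoro sits, and it too does not separate them; 4-methylphenyl, 3-fluorophenyl and 4-fluorophenyl on the sulfur are therefore interchangeable in this assay across compound 1, compound 3 and compound 4 at the one concentration tested. No measured property of these groups accompanies the result, so the data give no explanation for this flat reading.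

As far as these compounds go, whether this tolerance extends to other groups at the same place, such as an amine, a carboxylic acid or a longer alkyl chain, remains open. Also open, from the compounds shown here alone, is whether the much lower reading of compound 2, which carries 4-methylphenyl, would recur with 4-fluorophenyl on the same side chain.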